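The compounds below may be only part of what the source reports. "The series", "measured", "known", "first", "only" and "open" are said of these compounds alone.

Among the measured compounds shown here, in an ADME assay for permeability, using PAMPA, with a stated time of 4 h, at pH 7.4 (on this read-out higher numbers stand for higher permeability and lower numbers for lower permeability), compound 1 `CN(C)CCCCN(C[C@H]1Cc2ncccc2CN1)[C@H]1CCCc2cccnc21` gives 240 nm/s, and compound 2 `c1cnc2c(c1)CN[C@@H](CN(CCCCNC1CCOCC1)[C@H]1CCCc3cccnc31)C2` gives 8 nm/s, the lower of the two numbers so far. For the measured compounds named here, only one measured step is available: a 30-fold lower number from compound 1 to compound 2 (1.48 log units; beyond the scatter). It lies well beyond the scatter and is large, and it came from putting (oxan-4-yl)amino in place of dimethylamino.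

Compound 3 `c1cnc2c(c1)CN[C@@H](CN(CCCCN(C1COC1)C1COC1)[C@H]1CCCc3cccnc31)C2` is altered at that same place, on a saturated chain carbon, four bonds along the chain from an amine nitrogen: a group of 9 heavy atoms (6 carbon, 1 nitrogen, 2 oxygen; 2 four-membered non-aromatic rings with 1 hetero atom each) in place of a group of 7 heavy atoms (5 carbon, 1 nitrogen, 1 oxygen; one six-membered non-aromatic ring with 1 hetero atom), on a saturated chain carbon, four bonds along the chain from an amine nitrogen. Going by the values given here, the new group has not been measured in any other compound, so the single step is only a rough guide. It does show that the group at this place can move the number a long way. Unlike the group it replaces, the entering group has 0 hydrogen-bond donors, so a move back towards compound 1 at 240 nm/s is expected rather than a further fall, though probably not all the way.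

In this assay, the expected change is a 7.5-fold higher number from compound 2 to compound 3 (0.88 log units; beyond the scatter), beyond the scatter but smaller than the measured step. For compound 3 the estimated value is 60 nm/s, within an expected range of 15 nm/s to 200 nm/s.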

Compound 3, apparent permeability: 320 nm/s
Compound 3: the middle estimate sits 5.3-fold (0.73 log units) below what was measured, outside the stated range (above it).
By their numbers in this assay, from the lowest: compound 2; then compounds 1 and 3 (each within the scatter of the next).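

In this assay, the low number of compound 2 proves not to be a general result of putting a larger, ring-bearing group at this place on the chain: a 40-fold higher number from compound 2 to compound 3 (1.60 log units; beyond the scatter). Size alone does not set the number across these three compounds, since the entering group has 9 heavy atoms and two four-membered rings, yet a 1.3-fold higher number from compound 1 to compound 3 (0.12 log units; within the scatter), which leaves compound 3 and compound 1, with its 3-atom dimethylamino group and no ring, level within the scatter. No measurement here explains why the two large groups give such different numbers.

The step from compound 2 to compound 3 changes several things at once, including the ring size, the heavy-atom count and the loss of the hydrogen-bond donor, so the compounds shown leave open which of these matters. A methyl(oxan-4-yl)amino group, which keeps the six-membered ring but has no hydrogen on its nitrogen, would help separate these changes, while a morpholine ring would show how a second type of ring behaves at this place.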